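The source may hold more compounds than are shown below. What is called first, only, known or untested is meant among the compounds shown, and "the series" means these compounds.

Compound 1 `Cc1ccc(C)c(C(=O)c2c(OCC(=O)Nc3ccc(S(N)(=O)=O)cc3C)ccc3ccccc23)c1` — in an ADME assay on C8166 cells (Homo sapiens) for cytotoxicity, read by colorimetric assay and MTT assay (a higher number here means that more compound is tolerated, a lower number that less compound is tolerated), compound 1 gives 47500 nM.
Compound 2 `Cc1ccc(C(=O)c2c(OCC(=O)Nc3ccc(S(N)(=O)=O)cc3C)ccc3ccccc23)c(C)c1` — in this assay compound 2 gives 25500 nM.

Within the data shown here, compound 2 carries the smaller of the two numbers measured so far, but the only step connecting the two compounds, a 1.9-fold lower number from compound 1 to compound 2 (0.27 log units; within the scatter), is within the scatter, so the two cannot be told apart on these data. That step swaps the pattern of the two methyl groups on the dimethylphenyl attached to the carbonyl carbon and touches nothing else.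

Compound 3 `Cc1ccc(C(=O)c2c(OCC(=O)Nc3ccc(S(N)(=O)=O)cc3C)ccc3cc(Br)ccc23)c(C)c1` differs from compound 2 in a single place: bromo in place of hydrogen on an aromatic carbon. Among the measured compounds shown here, no measured step shows what a bromo on the fused ring system does in this assay. For the measured compounds named here, the one step on record changes a different part of the molecule, and it did not move the number beyond the scatter. There is therefore no basis for expecting a shift in either direction, and the expected step, a 1.0-fold lower number from compound 2 to compound 3 (0.01 log units; within the scatter), is one of no change beyond the scatter. Compound 3 is accordingly estimated to give about 25000 nM in this assay, with a plausible range from 9000 nM to 70000 nM.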

Compound 3, half-maximal cytotoxic concentration: 61400 nM
Beside the measured number, compound 3's estimate is 2.5-fold (0.39 log units) below it, and the stated range covers the measured number.
By their numbers in this assay, from the lowest: compounds 2, 1 and 3 (each within the scatter of the next, the first and the last beyond it).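

Putting a bromo in place of hydrogen on an aromatic carbon of the fused system of two rings gives a 2.4-fold higher number from compound 2 to compound 3 (0.38 log units; beyond the scatter) in this assay, a modest change in the direction of more compound tolerated. This is the first step among these compounds to lie beyond the scatter, whereas the earlier step, which rearranged the two methyl groups on the dimethylphenyl, did not. A single added heavy atom at this carbon, meta to a fused ring and para to a fused ring, can therefore shift the number measurably, while the size of that shift remains modest and rests on one pair of compounds. Nothing available here explains the shift, so the reason for it remains unknown.

The compounds shown leave open whether a chlorine, a methoxy group or an amine on the same aromatic carbon would shift the number in the same direction, or whether the effect belongs to bromo alone. They also leave open whether the same bromo would give a similar step on the 2,5-dimethylphenyl partner, compound 1.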